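The source may report more compounds than this note shows. Statements on the series, on what has been measured and on what is new or still open speak of the compounds shown alone.

Measured so far:
- compound 1, `COc1cc(-c2ccnc3cc(-c4ccc(C(C)=O)cc4)nn23)cc(OC)c1OC` — 4390 nM
- compound 2, `COc1cc(-c2ccnc3cc(-c4ccc(-c5cnn(C)c5)cc4)nn23)cc(OC)c1OC` — 2110 nM
- compound 3, `CCOC(=O)c1ccc(-c2cc3nccc(-c4cc(OC)c(OC)c(OC)c4)n3n2)cc1` — a limit, > 10000 nM

All three were tested in a functional assay on HCT-116 cells (Homo sapiens) for inhibition, read by CCK-8 assay, with a stated time of 48 h; on this read-out lower numbers stand for stronger inhibition and higher numbers for weaker inhibition. Among the two compounds with a number, compound 1 stands highest, and its nearest neighbour is compound 2, reached by a 2.1-fold lower number from compound 1 to compound 2 (0.32 log units; beyond the scatter). For compound 3 the result is only a limit, (the limit of > 10000 nM in this assay, at which 1 of the 3 values shown sits), so the step of an at least 2.2-fold higher number from compound 1 to compound 3 (0.35 log units; beyond the scatter) is known only as a minimum, as is an at least 4.7-fold higher number from compound 2 to compound 3 (0.67 log units; beyond the scatter).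

The unmeasured compound 4, `COc1cc(-c2ccnc3cc(-c4ccc5c(ccn5C)c4)nn23)cc(OC)c1OC`, differs from compound 1 by 1-methyl-1H-indol-5-yl in place of 4-acetylphenyl on an aromatic carbon. Among the measured compounds shown here, the step that bears on it most closely is the one from compound 1 to compound 2, where an aromatic ring replaced the acetyl group and the number fell by a 2.1-fold lower number from compound 1 to compound 2 (0.32 log units; beyond the scatter); the steps to compound 3 show that an ethoxycarbonyl group on the same aromatic carbon drove the number beyond the limit. A 1-methyl-1H-indol-5-yl group is again an aromatic ring system, so compound 4 is expected to show a modest lower number, a 2.2-fold lower number from compound 1 to compound 4 (0.34 log units; beyond the scatter). For compound 4 the estimate in this assay is 2000 nM, with a range from 700 nM to 6000 nM.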

Compound 4, half-maximal inhibitory concentration: 39 nM
The estimate for compound 4 lay 51-fold (1.71 log units) above the measured number; the whole stated range lies above it.
By their numbers in this assay, from the lowest: compound 4; then compound 2; then compound 1. At a limit, above all of these: compound 3.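

In this assay, among the compounds shown here, the 1-methyl-1H-indol-5-yl group in place of 4-acetylphenyl gives a 110-fold lower number from compound 1 to compound 4 (2.05 log units; beyond the scatter) and so shows that this aromatic carbon can shift the number far more than the one earlier step between two measured numbers, a 2.1-fold lower number from compound 1 to compound 2 (0.32 log units; beyond the scatter), had suggested. An added aromatic ring alone does not account for the result, as compound 2 also ends in a five-membered aromatic ring with a methyl group, yet compound 2 gives 2110 nM while compound 4 gives 39 nM. Nothing measured here explains this large gain.

Going by these compounds, it remains open whether the methyl group on the indole nitrogen matters, which the plain 1H-indol-5-yl group would test. Also open, on these data alone, is whether a benzofuran-5-yl or quinolin-6-yl group at this carbon would keep the gain.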